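Indole acetic acids as prostaglandin D2 receptor antagonists

The source may report more compounds than this note shows. Statements on the series, on what has been measured and on what is new or still open speak of the compounds shown alone.

Measured compounds:
- compound 1 `Cc1c(CC(=O)O)c2ccccc2n1C(=O)c1ccc(OC[C@@H]2CN(C)c3ccccc3O2)cc1`: "not determined" (no result reported)
- compound 2 `COc1cc(C(=O)n2c(C)c(CC(=O)O)c3ccccc32)ccc1OC[C@@H]1CN(C)c2ccccc2O1`: "not determined" (no result reported)
- compound 3 `Cc1cc(OC[C@@H]2CN(C)c3ccccc3O2)ccc1C(=O)n1c(C)c(CC(=O)O)c2cc(F)ccc21`: 3.2 nM

Among the compounds with values here, three compounds share the core; only one carries a number. Compound 1 and compound 2 have no result in a functional assay on CHO cells for antagonist activity at prostaglandin D2 receptor (Mus musculus), read by cAMP accumulation and immunoassay, with a stated time of 10 min, in the presence of a further agent that is not named here (a higher number here means a weaker inhibitor, a lower number a stronger inhibitor), and so give no footing for a comparison. Compound 3 is therefore the only anchor in this assay, and its value of 3.2 nM is the single point from which the series can be read. Nothing can be said about how compound 3 ranks against compound 1 or compound 2.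

Compound 4 `Cc1c(CC(=O)O)c2cc(F)ccc2n1C(=O)c1ccc(OC[C@@H]2CN(C)c3ccccc3O2)cc1Cl` is not yet measured. It differs from compound 3 in one place: chloro in place of methyl on an aromatic carbon, ortho to a large group and meta to a large group. Within the data shown here, no step between measured compounds exists to calibrate a change of this kind here, so the expectation rests on compound 3 alone. The step is expected to stay within the usual scatter, with no clear direction, a 1.3-fold higher number from compound 3 to compound 4 (0.10 log units; within the scatter). Compound 4 is estimated at 4 nM in this assay, with a range from 1.5 nM to 12 nM.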

Compound 4, half-maximal inhibitory concentration: 1.6 nM
Compound 4: middle estimate off by 2.5-fold (0.40 log units), on the high side; measured number inside the range.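

Read in this assay the exchange gives a 2.0-fold lower number from compound 3 to compound 4 (0.30 log units; within the scatter) and so does not separate chloro from methyl on this aromatic carbon, ortho to a large group and meta to a large group. The earlier compounds shown here offered a single number and no step, whereas this pair gives the series its first calibrated change at this position, showing that activity in this assay is retained with either group in place. No measurement at hand bears on why the two groups read alike, and this single pair supports no wider pattern.

Going by these compounds, whether a nitrile, a trifluoromethyl, an amine or a longer chain on the same aromatic carbon would read like chloro and methyl remains open. Within the data shown here, also open is whether the exchange of methyl for chloro would read the same with other groups elsewhere on the shared core, as only one pair carries it so far.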